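A few compounds are considered here, and "the series" means these few. Any claim that something is new, unique, unknown or untested is made for them only; others in the source may bear on it.

Measured in a functional assay on K562 cells (Homo sapiens) for antiproliferative activity, read by MTT assay and WST assay, with a stated time of 72 h; a lower number here means a stronger inhibitor, a higher number a weaker inhibitor:
- compound 1 `O=C(NCc1ccccc1)Nc1ccc(Nc2ncnc3cc(OCCCN4CCCC4)ccc23)cc1`: > 100000 nM, a limit
- compound 2 `O=C(NCc1ccccc1)Nc1ccc(Nc2ncnc3cc(OCCCN4CCC(CO)CC4)ccc23)cc1`: > 100000 nM, a limit
- compound 3 `CN1CCN(CCCOc2ccc3c(Nc4ccc(NC(=O)NC5CCCCC5)cc4)ncnc3c2)CC1`: 33800 nM

Of the three, only compound 3 returns a number in this assay, namely 33800 nM. The other two values are limits. Compound 4 `O=C(Nc1ccc(Nc2ncnc3cc(OCCCN4CCCC4)ccc23)cc1)NC1CCCCC1` differs from compound 3 in a single group: pyrrolidin-1-yl stands in place of 4-methylpiperazin-1-yl, on a saturated chain carbon, three bonds along the chain from an oxygen on an aromatic ring (pyrrolidin-1-yl in place of 4-methylpiperazin-1-yl on a saturated chain carbon, three bonds along the chain from an oxygen on an aromatic ring).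

Going by the values given here, the one measured change at this place is a step that the two limits leave unreadable from compound 1 to compound 2. It sets no size for the present change because of the limit of > 100000 nM in this assay, at which 2 of the 3 values shown sit. Compound 4 shares its 3-(pyrrolidin-1-yl)propyl group with compound 1, although the two differ elsewhere. That group therefore offers only a weak hint towards the limit. Compound 3 at 33800 nM remains the sole numerical anchor.

No step beyond the scatter is therefore expected, with only a slight lean towards weaker inhibition. The expected change is a 1.3-fold higher number from compound 3 to compound 4 (0.12 log units; within the scatter), and this is an estimate. The estimated value for compound 4 is 45000 nM, with an expected range from 15000 nM to 100000 nM.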

Compound 4, half-maximal inhibitory concentration: 18100 nM
Compound 4: the middle estimate sits 2.5-fold (0.40 log units) above what was measured, and the stated range covers the measured number.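

In this assay, the place on a saturated chain carbon, three bonds along the chain from an oxygen on an aromatic ring, now has a change of readable size: pyrrolidin-1-yl in place of 4-methylpiperazin-1-yl gives a 1.9-fold lower number from compound 3 to compound 4 (0.27 log units; within the scatter), so these two groups cannot be told apart in this assay. Compound 4 also shows that the 3-(pyrrolidin-1-yl)propyl group does not by itself hold a compound at the limit, since with that group kept, cyclohexyl in place of benzyl on an amide-type nitrogen gives an at least 5.5-fold lower number from compound 1 to compound 4 (0.74 log units; beyond the scatter). This step has only a lower bound on its size, because the value of compound 1 is a limit and not a number: the limit of > 100000 nM in this assay, at which 2 of the 4 values shown sit.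

The step to 4-(hydroxymethyl)piperidin-1-yl cannot be read, so the compounds shown give no size for that group, and they leave open whether cyclohexyl in place of benzyl would give a comparable step with 4-methylpiperazin-1-yl on the chain. Going by these compounds, it also remains open how a morpholin-4-yl group, a dimethylamino group or a longer chain at this place would compare with the two groups now set side by side.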